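Methoxy for Nitro: a Cytotoxicity Step on HT-29 Cells

A few compounds are considered here, and "the series" means these few. Any claim that something is new, unique, unknown or untested is made for them only; others in the source may bear on it.

compound 1 `CCCc1n[nH]c2c(=O)n(NC(=O)c3ccccc3)c(-c3cccc(OC)c3)nc12`: 6.27%
compound 2 `O=C(Nn1c(-c2cccc([N+](=O)[O-])c2)nc2c(-c3cccc(Cl)c3)n[nH]c2c1=O)c1ccccc1`: 89.8%

In a functional assay on HT-29 cells (Homo sapiens) for cytotoxicity, read by sulforhodamine B assay, with a stated time of 2 days, tested at 100 uM (on this read-out lower numbers stand for less inhibition and higher numbers for more inhibition at the one concentration tested (going by the name of the read-out)), compound 2 gives 89.8%, the higher of the two numbers, while compound 1 gives 6.27%, a gap far beyond the scatter. Compound 3 `COc1cccc(-c2nc3c(-c4cccc(Cl)c4)n[nH]c3c(=O)n2NC(=O)c2ccccc2)c1` has not been measured; it differs from compound 2 by methoxy in place of nitro on an aromatic carbon. Within the data shown here, no measured pair shows this exact change, and compound 1 differs from compound 3 in a second place as well, so the expectation is loose. A drop in this assay beyond the scatter is expected, partly since compound 1 also carries methoxy and gives 6.27%. Compound 3 is estimated at 45%, within 8% to 88%. The expected step is a number 44.8 percentage points lower from compound 2 to compound 3 (beyond the scatter).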

Compound 3, a percentage reported as inhibition, at one concentration (the size of the read-out at that concentration, not a potency): 91%
Estimate against measurement, compound 3: 46 percentage points below; measured number outside the range, above it.
By their numbers in this assay, from the lowest: compound 1; then compounds 2 and 3 (each within the scatter of the next).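

In this assay, with 3-chlorophenyl held in the other place, the change from 3-nitrophenyl to 3-methoxyphenyl cannot be told apart from scatter: a number 1.2 percentage points higher from compound 2 to compound 3 (within the scatter). Methoxy at this position is therefore compatible with a high read-out, and the large difference appears instead with 3-chlorophenyl in place of propyl: a number 84.7 percentage points higher from compound 1 to compound 3 (beyond the scatter). Nothing here gives a reason for either step.

On these data alone, whether an amine or a carboxylic acid on this aromatic carbon would read alike remains open. So does whether nitro and methoxy would also match with propyl in the other place.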